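The source may hold more compounds than are shown below. What is called first, only, known or untested is meant among the compounds shown, and "the series" means these compounds.

Working notes on the series. Within the data shown here, in a functional assay on HeLa cells (Homo sapiens) for cytotoxicity, read by MTT assay, with a stated time of 24 h (on this read-out lower numbers stand for stronger inhibition and higher numbers for weaker inhibition), compound 1 `COc1ccc(Cc2cn3cc(Br)ccc3nc2=O)cc1` gives 928000 nM, the only actual number obtained so far. Compound 2 `Cc1ccc(Cc2cn3cc(Cl)ccc3nc2=O)cc1` is reported as > 1000000 nM, and this is a limit of the assay and not a number. Among the measured compounds shown here, with one number and one limit, the series offers no measured step between compounds, and nothing yet shows how any single change moves the read-out.

The next compound is compound 3 `O=c1nc2ccc(Br)cn2cc1Cc1ccccc1`. It differs from compound 1 by hydrogen in place of methoxy on an aromatic carbon, para to a large group, on a six-membered aromatic ring of carbon only: hydrogen in place of methoxy on an aromatic carbon.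

For the measured compounds named here, no measured pair isolates this change, so any expectation for it is weakly founded. In this assay, no step beyond the usual scatter is expected. This expectation rests on compound 1 at 928000 nM. It also rests on (the limit of > 1000000 nM in this assay, at which 1 of the 2 values shown sits), and a report of compound 3 as a limit would be no surprise. The estimated 1.1-fold higher number from compound 1 to compound 3 (0.03 log units; within the scatter) is small, in no clear direction. For compound 3 the estimated value is 1000000 nM, with an expected range of 500000 nM to 2000000 nM.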

Compound 3, half-maximal inhibitory concentration: 152000 nM
For compound 3 the middle estimate is 6.6-fold (0.82 log units) above the measured one; measured number outside the range, below it.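

In this assay, among these compounds, the first measured step is a 6.1-fold lower number from compound 1 to compound 3 (0.79 log units; beyond the scatter), beyond the scatter, so hydrogen in place of methoxy on this aromatic carbon, para to a large group, does move the read-out. The direction is towards the lower number, which means stronger inhibition on this read-out, and the methoxy is not needed for the activity seen here. Among the compounds shown here, neither the single number for compound 1 nor the limit for compound 2 could show that this place responds to a change, although this remains one pair and gives no reason for the size of the step.

For the compounds shown here, compound 2 stands as a limit of the assay and not a number, so it gives no step and leaves the series resting on few values: the limit of > 1000000 nM in this assay, at which 1 of the 3 values shown sits. Whether an amine, a carboxylic acid or a fluorine at this same place would stay with hydrogen or with methoxy remains open, as does whether the step would hold with any other substituent on the shared core.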